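The source may hold more compounds than are shown below. What is called first, only, known or untested is meant among the compounds shown, and "the series" means these compounds.

Measured so far in a functional assay on NCI-H460 cells (Homo sapiens) for cytotoxicity, read by MTT assay, with a stated time of 72 h; on this read-out lower numbers stand for stronger inhibition and higher numbers for weaker inhibition
- compound 1 `CC1CCN(Cc2ccc3nc(NC(=O)N/N=C/c4cn(Cc5ccccc5Cl)c5ccccc45)sc3c2)CC1` gives 1080 nM
- compound 2 `CC1CCN(Cc2ccc3nc(NC(=O)N/N=C/c4cn(Cc5ccc(Cl)cc5)c5ccccc45)sc3c2)CC1` gives 400 nM

Compound 2 holds the lower of these two numbers, so it is the stronger inhibitor of the pair. Compound 3 `CC1CCN(Cc2ccc3nc(NC(=O)N/N=C/c4cn(Cc5ccc(C(C)(C)C)cc5)c5ccccc45)sc3c2)CC1` differs from it in one group, with tert-butyl in place of chloro on an aromatic carbon. Within the data shown here, only one measured step bears on this (a 2.7-fold lower number from compound 1 to compound 2 (0.43 log units; beyond the scatter)). That step is modest, and it moved the chlorine rather than replacing it. Nothing measured shows what a tert-butyl does in this assay and so no clear step beyond the scatter is expected. The estimated step is small (a 1.3-fold higher number from compound 2 to compound 3 (0.10 log units; within the scatter)). For compound 3 the expected value is near 500 nM within an estimated range (150 nM to 1600 nM).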

Compound 3, half-maximal inhibitory concentration: 3370 nM
Beside the measured number, compound 3's estimate is 6.7-fold (0.83 log units) below it, and the stated range ends below it.
By their numbers in this assay, from the lowest: compound 2; then compound 1; then compound 3.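

In this assay the group on this ring carbon matters, not only where a chlorine sits: tert-butyl in place of chloro gives an 8.4-fold higher number from compound 2 to compound 3 (0.93 log units; beyond the scatter). The 4-(tert-butyl)phenyl group also gives a weaker result than the 2-chlorophenyl group, with a 3.1-fold higher number from compound 1 to compound 3 (0.49 log units; beyond the scatter). No measurement at hand accounts for this loss.

The compounds shown leave open how a methyl, a methoxy or an amine would read at this same place. They also leave open whether a group with fewer heavy atoms than tert-butyl would hold the number of compound 2.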